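Methyl added to the phenyl ring of a coumarin-bearing pyrazole

A few compounds are considered here, and "the series" means these few. Any claim that something is new, unique, unknown or untested is made for them only; others in the source may bear on it.

Compound 1 `COC(=O)c1c(-c2cc3ccccc3oc2=O)nn(-c2ccccc2)c1C(=O)OC` is the stronger of two compounds tested in a functional assay on HeLa cells (Homo sapiens) for cytotoxicity, read by MTT assay, with a stated time of 48 h (a lower number here means a stronger inhibitor, a higher number a weaker inhibitor), giving 35000 nM, while compound 2 `CCOC(=O)c1c(-c2cc3ccccc3oc2=O)nn(-c2cccc(C)c2)c1C(=O)OCC` in this assay gives 245000 nM. Compound 3 `COC(=O)c1c(-c2cc3ccccc3oc2=O)nn(-c2cccc(C)c2)c1C(=O)OC` differs from compound 1 by methyl in place of hydrogen on an aromatic carbon, on an aromatic carbon of a six-membered aromatic ring of carbon only, meta to a large group. Within the data shown here, no single step between measured compounds shows what this change does on its own, so the expected step from compound 1 to compound 3 in this assay is a 2.3-fold higher number from compound 1 to compound 3 (0.36 log units; beyond the scatter), a modest loss, wider than the scatter but uncertain. Compound 3 is therefore expected to give 80000 nM, within 30000 nM to 250000 nM.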

Compound 3, half-maximal inhibitory concentration: 45000 nM
The estimate for compound 3 lay 1.8-fold (0.25 log units) above the measured number, and the stated range covers the measured number.
By their numbers in this assay, from the lowest: compounds 1 and 3 (each within the scatter of the next); then compound 2.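

Among these compounds, this is the first step in the set that isolates one change: going from phenyl to 3-methylphenyl gives a 1.3-fold higher number from compound 1 to compound 3 (0.11 log units; within the scatter) in this assay with the rest of the molecule held the same. A methyl at this place, on a carbon meta to a large group, therefore leaves the number within the scatter. No measurement shown explains this result.

From the compounds shown here alone, what remains open is whether an amine, a carboxylic acid or a longer chain at this same place would shift the number. A methyl on the other carbons of this ring is also untested among these compounds.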